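The compounds below may be only part of what the source reports. "The series", "measured", "known", "first", "only" and "open" are said of these compounds alone.

Measured so far in an ADME assay (liver) for metabolic stability, with Liver microsome (Rattus norvegicus) as the target, read by LC-MS, using microsomes and NADPH, with stated times of 5 min and 60 min, tested at 4 uM; a lower number here means that less of the compound is left, a higher number that more of the compound is left:
compound 1 `Cc1c(OCCCCOc2ccc(C(=O)O)cc2Cl)ccc(C(=O)CC2CCCC2)c1O`: 21%
compound 2 `Cc1c(OCCCCOc2cccc(C(=O)O)c2)ccc(C(=O)CC2CCCC2)c1O`: 55%

Within the data shown here, of these two, compound 2 stands highest at 55%, clear of the only other measured number.

Next in the series is compound 3 `COc1ccc(C(=O)O)cc1OCCCCOc1ccc(C(=O)CC2CCCC2)c(O)c1C`, which differs from compound 2 by methoxy in place of hydrogen on an aromatic carbon, so that 3-carboxyphenyl becomes 5-carboxy-2-methoxyphenyl: methoxy in place of hydrogen on an aromatic carbon.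

Among the measured compounds shown here, only one measured step bears on this change, and only indirectly. It is a number 34 percentage points higher from compound 1 to compound 2 (beyond the scatter), a large step, in which 3-carboxyphenyl replaces 4-carboxy-2-chlorophenyl. That step moves the carboxy group and removes the chloro group together, so the data do not separate the two. For the measured compounds named here, no measured pair isolates methoxy. Compound 3 keeps the carboxy placing of compound 2 and adds a substituent, as compound 1 also carries one, so a small fall is expected, much smaller than the measured step and perhaps not beyond the scatter.

The expected change is a number 10 percentage points lower from compound 2 to compound 3 (within the scatter). For compound 3 the estimated value is 45%, with an expected range of 25% to 65%.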

Compound 3, percent of the compound remaining: 14%
Compound 3: middle estimate off by 31 percentage points, on the high side; measured number outside the range, below it.
By their numbers in this assay, from the lowest: compounds 3 and 1 (each within the scatter of the next); then compound 2.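

In this assay, methoxy in place of hydrogen on the aromatic carbon ortho to a large group and para to a carboxy group is a large change on its own, a number 41 percentage points lower from compound 2 to compound 3 (beyond the scatter), and this single-place step shows that the carboxyphenyl ring is sensitive to substitution at this position, which the earlier pair could not show, with the chloro group and the carboxy placing changing together there. The step of a number 7 percentage points lower from compound 1 to compound 3 (within the scatter) puts the two compounds carrying a second substituent on this ring within the scatter of each other despite their different substitution, leaving compound 2, with only the carboxy group on that ring, as the one clear of both. Nothing available accounts for the fall at this position.

Still open, going by these compounds, is whether the fall belongs to methoxy specifically or would follow any group at this carbon, a question that a fluoro, hydroxy or ethoxy group at the same place would address. Also open, on these data alone, is how much of the difference between compound 1 and compound 2 comes from the chloro group and how much from the carboxy placing.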